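A few compounds are considered here, and "the series" means these few. Any claim that something is new, unique, unknown or untested is made for them only; others in the source may bear on it.

Measured so far in an assay on isolated protein for binding affinity to secreted frizzled-related protein 1 (Homo sapiens), read by fluorescence; on this read-out higher numbers stand for weaker inhibition and lower numbers for stronger inhibition:
compound 1 `CN(C)CC(=O)N1CCC(NS(=O)(=O)c2cc(S(=O)(=O)c3ccccc3)ccc2C(F)(F)F)CC1` — 300 nM
compound 2 `O=C(CN1CCNCC1)N1CCC(NS(=O)(=O)c2cc(S(=O)(=O)c3ccccc3)ccc2C(F)(F)F)CC1` — 140 nM
compound 3 `O=C([C@@H]1CCCN1C(=O)N1CCOCC1)N1CCC(NS(=O)(=O)c2cc(S(=O)(=O)c3ccccc3)ccc2C(F)(F)F)CC1` — 40 nM

Compound 3 gives the lowest number of the three, and its gaps to compound 2 and to compound 1 both lie beyond the scatter. Compound 4 `O=C([C@@H]1CCCN1Cc1ccccc1)N1CCC(NS(=O)(=O)c2cc(S(=O)(=O)c3ccccc3)ccc2C(F)(F)F)CC1` is the next point on the amide side chain. Against compound 3 the change is benzyl in place of (morpholin-4-yl)carbonyl on an amine nitrogen in a ring.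

Among the compounds with values here, the only measured single step, a 2.1-fold lower number from compound 1 to compound 2 (0.33 log units; beyond the scatter), lies on the same side chain but exchanges one amine for another on a chain carbon; it says nothing about replacing a carbonyl-bearing group with benzyl on the ring nitrogen. Within the data shown here, the step from compound 3 to compound 4 therefore has no direct precedent. With the two acceptors of the (morpholin-4-yl)carbonyl removed and an aromatic ring entering, compound 4 is expected to stay near compound 3 in this assay, with a step of a 1.5-fold higher number from compound 3 to compound 4 (0.18 log units; within the scatter) and a wide range: estimate 60 nM, between 15 nM and 250 nM.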

Compound 4, half-maximal inhibitory concentration: 1400 nM
Compound 4: the middle estimate sits 23-fold (1.37 log units) below what was measured; the measured number lies above the stated range.
By their numbers in this assay, from the lowest: compound 3; then compound 2; then compound 1; then compound 4.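

In this assay, within the data shown here, the amine nitrogen in the five-membered ring proves sensitive to what it carries: benzyl in place of (morpholin-4-yl)carbonyl gives a 35-fold higher number from compound 3 to compound 4 (1.54 log units; beyond the scatter), the largest step so far. The ring on the carbonyl carbon does not by itself bring the low number of compound 3, as 1-benzylpyrrolidin-2-yl also trails both open-chain side chains, with a 10-fold higher number from compound 2 to compound 4 (1.00 log units; beyond the scatter) and a 4.7-fold higher number from compound 1 to compound 4 (0.67 log units; beyond the scatter). Nothing at hand accounts for this loss.

Open, from the compounds shown here alone, is whether the carbonyl or the morpholine ring of the (morpholin-4-yl)carbonyl matters more, which an acetyl or a (piperidin-1-yl)carbonyl on that nitrogen would help to separate. Also open, going by these compounds, is whether the aromatic ring of benzyl carries the loss, which a cyclohexylmethyl group there would test.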